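The compounds below may be only part of what the source reports. "The series", "measured", "known", "first", "only" and "open" are said of these compounds alone.

Compound 1 `CCCCCCCCCCCCO/N=C(\CCCCCC)c1cc(OC)c2c(c1OC)C(=O)C=CC2=O` was tested in a functional assay on A549 cells (Homo sapiens) for antiproliferative activity; a higher number here means that more compound is needed for the effect, a lower number that less compound is needed. For compound 1 the result is a limit of the assay rather than a number, > 10 ug/mL. Compound 2 `CO/N=C/c1cc(OC)c2c(c1OC)C(=O)C=CC2=O` likewise gives only a limit, > 10 ug/mL. Both results sit at the limit of > 10 ug/mL in this assay, at which 2 of the 2 values shown sit, so the two cannot be ranked against each other. Compound 3 `CCCCCC/C(=N\OCCCCC)c1cc(OC)c2c(c1OC)C(=O)C=CC2=O` differs from compound 1 by hydrogen in place of heptyl on a saturated chain carbon, five bonds along the chain from an oxygen on an unsaturated carbon. For the measured compounds named here, no measured pair shows what such a shortening does in this assay, so the step from compound 1 to compound 3 is expected to be a step that the limit leaves unreadable from compound 1 to compound 3, none beyond the scatter. Compound 3 is therefore estimated at 12 ug/mL, between 5 ug/mL and 30 ug/mL.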

Compound 3, concentration for half-maximal effect: > 10 ug/mL
Compound 3: only a limit was reported; the forecaster's own chance of this, stated with the estimate: 70%; the middle value does not contradict the limit.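

In this assay, for the compounds shown here, compound 3, like compound 1, gives only a limit, so no step between the two can be read. The compounds shown leave open whether changing chain length alters antiproliferative activity at all.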